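The compounds below may be only part of what the source reports. "The series", "measured", "known", "first", "only" and "open" are said of these compounds alone.

In a functional assay on HeLa cells (Homo sapiens) for inhibition, with a stated time of 48 h, tested at 50 uM (on this read-out higher numbers stand for more inhibition of growth at the one concentration tested and lower numbers for less inhibition of growth), compound 1 (`COc1ccc(/C=C/[C@@](C)(/C=C/c2ccc(O)cc2)CCC=C(C)C)cc1`) gives 20% and stands lowest of three numbers, while compound 2 (`CC(C)=CCCC(C)(/C=C/c1ccc(O)cc1)/C=C/c1ccc(O)cc1`) gives 32% and compound 3 (`CC(C)=CCC[C@](C)(/C=C/c1ccc(O)cc1)/C=C/c1ccc(F)cc1`) gives 43% in the same test. Compound 4 (`COc1ccc(/C=C/[C@@](C)(/C=C/c2ccc(O)cc2)CCC=C(C)C)cc1CO`) differs from compound 1 by hydroxymethyl in place of hydrogen on an aromatic carbon and this means hydroxymethyl in place of hydrogen on an aromatic carbon, ortho to a methoxy group. Two measured steps alter that methoxy group: a number 12 percentage points higher from compound 1 to compound 2 (beyond the scatter) with hydrogen in place of its methyl, and a number 23 percentage points higher from compound 1 to compound 3 (beyond the scatter) with fluoro in its place. Neither touches the carbon changing here, so they show only that modest moves are possible, and no step beyond the scatter is expected. The expected change is a number 3 percentage points higher from compound 1 to compound 4 (within the scatter) in this comparison. In this assay the estimate for compound 4 is 23% with an expected range from 8% to 38% on measurement.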

Compound 4, percent growth inhibition at one concentration: 36%
The estimate for compound 4 lay 13 percentage points below the measured number; measured number inside the range.
By their numbers in this assay, from the lowest: compound 1; then compounds 2, 4 and 3 (each within the scatter of the next, the first and the last beyond it).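

In this assay hydroxymethyl in place of hydrogen gives a number 16 percentage points higher from compound 1 to compound 4 (beyond the scatter) and so shows that the aromatic carbon ortho to a methoxy group can itself change growth inhibition. The earlier steps shown here altered only the methoxy group, whereas here that group stays in place and a new group is added to the ring. No measurement available here explains this gain.

As far as these compounds go, it remains open whether the oxygen of hydroxymethyl matters, since a plain methyl, an aminomethyl or a carboxylic acid on this carbon would be needed to test that.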